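Replacing the pyrrolidine amide with an acyl sulfonamide

This account rests on a few compounds, and the source may have more. Where it says the series, first, only, none or still open, it means among the compounds named here.

Among the measured compounds shown here, compound 2 `Cc1cc(C)cc(S(=O)(=O)c2c(C(=O)N[C@H]3CCN(S(C)(=O)=O)C3)[nH]c3ccc(Cl)cc23)c1` carries the highest of the two numbers measured so far in an ADME assay on MT4 cells (Homo sapiens) for cytotoxicity, read by MTT assay, with a stated time of 5 days (a higher number here means that more compound is tolerated, a lower number that less compound is tolerated), where it gives 29900 nM; its nearest neighbour is compound 1 `Cc1cc(C)cc(S(=O)(=O)c2c(C(=O)N[C@H]3CCN(Cc4n[nH]c(=O)n4C)C3)[nH]c3ccc(Cl)cc23)c1`, which in this assay gives 21500 nM. For the measured compounds named here, the only step among the measured pair, a 1.4-fold higher number from compound 1 to compound 2 (0.14 log units; within the scatter), changes a group on the ring amine nitrogen and leaves the tolerated concentration where it was.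

Compound 3 `Cc1cc(C)cc(S(=O)(=O)c2c(C(=O)NS(=O)(=O)c3ccc(F)cc3)[nH]c3ccc(Cl)cc23)c1` departs from compound 2 at a different place: (4-fluorophenyl)sulfonyl in place of 1-(methylsulfonyl)pyrrolidin-3-yl on an amide-type nitrogen. Going by the values given here, no measured step touches the amide-type nitrogen or removes the five-membered non-aromatic ring, so the one step on record, a 1.4-fold higher number from compound 1 to compound 2 (0.14 log units; within the scatter), bears on this change only in showing that a swap at the periphery of the shared core left cytotoxicity unchanged. On that basis the author expects compound 3 to stay near compound 2 in this assay, with a 1.2-fold lower number from compound 2 to compound 3 (0.08 log units; within the scatter) as the expected step and no movement beyond the scatter. Compound 3 is therefore estimated at 25000 nM, within a range from 8000 nM to 80000 nM.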

Compound 3, half-maximal cytotoxic concentration: > 252000 nM
Compound 3 gave a limit, no number; the forecaster's own chance of this, stated with the estimate: 25%; middle value at least 10-fold (1.00 log units) from the limit.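

In this assay, the position on the amide-type nitrogen proves far more responsive than the ring amine nitrogen: an at least 8.4-fold higher number from compound 2 to compound 3 (0.92 log units; beyond the scatter), whereas the earlier change gave a 1.4-fold higher number from compound 1 to compound 2 (0.14 log units; within the scatter). The result for compound 3 is a limit of the assay and not a number: the limit of > 252000 nM in this assay, at which 1 of the 3 values shown sits. The step therefore shows that exchanging 1-(methylsulfonyl)pyrrolidin-3-yl for (4-fluorophenyl)sulfonyl at this nitrogen can raise the tolerated concentration beyond the scatter, which the change on the ring amine nitrogen did not do.

This single exchange alters several things together: it removes the five-membered non-aromatic ring and the defined stereocentre and brings in the sulfonyl link, a six-membered aromatic ring of carbon only and a fluorine, so the compounds shown cannot say which of these accounts for the step. Going by these compounds, a plain phenylsulfonyl or a methylsulfonyl on the same nitrogen would separate the aromatic ring and the fluorine from the sulfonyl link, and how far compound 3 really lies from compound 2 remains unknown while its result stands as a limit.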